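A few compounds are considered here, and "the series" means these few. Any claim that something is new, unique, unknown or untested is made for them only; others in the source may bear on it.

For the measured compounds named here, in a functional assay on HepG2 cells (Homo sapiens) for antiproliferative activity, read by MTT assay, with a stated time of 48 h (on this read-out higher numbers stand for weaker inhibition and lower numbers for stronger inhibition), compound 2 (`CCn1c(C(=O)N(C)CC(=O)O)ccc1C(CC)(CC)c1ccc(OCCC(O)(CC)CC)c(C)c1`) gives 5710 nM as the only true number so far. Compound 1 (`CCn1c(C(=O)Nc2ccc(OC(F)(F)F)cc2)ccc1C(CC)(CC)c1ccc(OCCC(O)(CC)CC)c(C)c1`) shows > 50000 nM in this assay and that is a limit of the assay, not a number.

Compound 3 (`CCn1c(C(=O)NC(C)C(=O)O)ccc1C(CC)(CC)c1ccc(OCCC(O)(CC)CC)c(C)c1`) keeps the shared core and differs from compound 2 in one place, on a carbonyl carbon whose other neighbour is an aromatic carbon: (1-carboxyethyl)amino stands in place of (carboxymethyl)(methyl)amino. The full count of the change is (1-carboxyethyl)amino in place of (carboxymethyl)(methyl)amino on a carbonyl carbon and the two compounds hold the same atoms, joined differently.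

Going by the values given here, only one measured step touches this place. an at least 8.7-fold lower number from compound 1 to compound 2 (0.94 log units; beyond the scatter) lies beyond the scatter, but one end of it rests on the limit of > 50000 nM in this assay, at which 1 of the 2 values shown sits, so its true size stays open. Among the compounds with values here, that step replaced (4-(trifluoromethoxy)phenyl)amino, a different exchange from the one here, and no measured step shows the present swap directly.

With the same atoms in compound 3, a value near that of compound 2 at 5710 nM is expected. The expected change is a 1.1-fold higher number from compound 2 to compound 3 (0.02 log units; within the scatter) and so none beyond the scatter. In this assay the estimated value for compound 3 is 6000 nM with a likely range from 2000 nM to 20000 nM for now.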

Compound 3, half-maximal inhibitory concentration: 1740 nM
Compound 3: middle estimate off by 3.4-fold (0.54 log units), on the high side, outside the stated range (below it).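

Moving atoms around at this position, without adding or removing any, is enough to change the result in this assay: the swap on the carbonyl carbon gives a 3.3-fold lower number from compound 2 to compound 3 (0.52 log units; beyond the scatter). The entering (1-carboxyethyl)amino group carries 2 hydrogen-bond donors where the leaving (carboxymethyl)(methyl)amino group carries 1, and its methyl group also sits on carbon rather than on nitrogen, and this single pair cannot tell these two differences apart. The value of compound 1 is a limit and not a number, which leaves the full size of an at least 28-fold lower number from compound 1 to compound 3 (1.45 log units; beyond the scatter) open, since one end of that step rests on this limit: the limit of > 50000 nM in this assay, at which 1 of the 3 values shown sits.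

As far as these compounds go, whether the change follows the amide hydrogen or the methyl branch remains open, and the plain (carboxymethyl)amino group, with neither methyl, would separate the two. The compounds shown also leave open what the carboxylic acid itself contributes, a question that a methyl ester or a primary amide at the same place would address.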